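This account rests on a few compounds, and the source may have more. Where it says the series, first, only, none or still open, it means among the compounds named here.

In a toxicity assay on NIH3T3 cells (Mus musculus) for cytotoxicity, read by resazurin assay (on this read-out higher numbers stand for an effect only at larger amounts of compound and lower numbers for an effect already at smaller amounts), compound 1 (`CC(C)c1ccc(Cn2cncc2CNc2ccc(-c3nc4ccccc4s3)c(-c3ccccc3)c2)cc1`) gives > 1000 nM, which is a limit of the assay and not a number. Compound 2 (`COC(=O)c1ccc(NCc2cncn2Cc2cccc(C#N)c2)cc1-c1ccccc1`) gives > 10000 nM in this assay, and this too is a limit. Among the compounds with values here, compound 1 therefore has no exact value, and neither does the only other compound measured so far. Within the data shown here, no measured pair differs in a single place, so no measured step shows what one such change does here. Compound 3 (`CS(=O)(=O)c1ccc(Cn2cncc2CNc2ccc(-c3nc4ccccc4s3)c(-c3ccccc3)c2)cc1`) has methylsulfonyl in place of isopropyl on an aromatic carbon, para to a large group: methylsulfonyl in place of isopropyl on an aromatic carbon. The expected change in this assay is a step that the limit leaves unreadable from compound 1 to compound 3, an estimated move towards higher numbers, and the assay may well report only a limit again. For compound 3, the estimated value is 6000 nM, with an expected range from 1500 nM to 30000 nM.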

Compound 3, half-maximal effective concentration: > 1000 nM
Compound 3 gave a limit, no number; the forecaster's own chance of this, stated with the estimate: 65%; the middle value lies beyond the limit too.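

Compound 1 and compound 3 both stand only as limits in this assay, so no step between them can be read: the limit of > 1000 nM in this assay, at which 2 of the 3 values shown sit.

The compounds shown leave open where any exact value lies, and whether methylsulfonyl in place of isopropyl on an aromatic carbon changes it at all.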